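Replacing one trifluoromethyl in compound 2

The source may hold more compounds than are shown below. What is called first, only, known or untested is meant among the compounds shown, and "the series" means these compounds.

For the measured compounds named here, in a functional assay on HepG2 cells (Homo sapiens) for cytotoxicity, read by MTT assay, with a stated time of 24 h (on this read-out higher numbers stand for weaker inhibition and lower numbers for stronger inhibition), compound 2 (`O=C1/C(=C/c2ccncc2)CN(S(=O)(=O)c2ccc(C(F)(F)F)cc2)C/C1=C\c1ccccc1C(F)(F)F`) gives 3240 nM, the lower of the two numbers so far, and compound 1 (`O=C1/C(=C/c2ccncc2)CN(S(=O)(=O)c2ccc(F)cc2)C/C1=C\c1ccccc1F`) gives 20300 nM, a gap beyond the scatter. Compound 3 (`O=C1/C(=C/c2ccncc2)CN(S(=O)(=O)c2ccc(F)cc2)C/C1=C\c1ccccc1C(F)(F)F`) has fluoro in place of trifluoromethyl on an aromatic carbon, para to a large group: fluoro in place of trifluoromethyl on an aromatic carbon. Going by the values given here, no step at a single place has been measured, so the expectation rests on these two values alone. A rise beyond the scatter in this assay is expected, estimated as a 2.5-fold higher number from compound 2 to compound 3 (0.39 log units; beyond the scatter). The number is expected to stay under that of compound 1 at 20300 nM. For compound 3 the estimate is 8000 nM, with an expected range of 3500 nM to 18000 nM.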

Compound 3, half-maximal inhibitory concentration: 4010 nM
For compound 3 the middle estimate is 2.0-fold (0.30 log units) above the measured one; low and high end bracket the measured number.
By their numbers in this assay, from the lowest: compounds 2 and 3 (each within the scatter of the next); then compound 1.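

In this assay the change from 4-(trifluoromethyl)phenyl to 4-fluorophenyl leaves the number within the scatter (a 1.2-fold higher number from compound 2 to compound 3 (0.09 log units; within the scatter)), so this read-out does not separate fluoro from trifluoromethyl at this aromatic carbon. The other place that differs does show a step beyond the scatter, though a modest one (a 5.1-fold lower number from compound 1 to compound 3 (0.70 log units; beyond the scatter)). No measured evidence bears on the cause of either step. From the compounds shown here alone, whether an amine, a carboxylic acid or a longer chain at this aromatic carbon would also leave the number within the scatter remains open.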